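From 4-bromophenyl to 2-methoxyphenyl on a shared core

The source may hold more compounds than are shown below. What is called first, only, known or untested is meant among the compounds shown, and "the series" means these compounds.

Compound 1 `CCCc1ccc(NC2=CC(=O)c3nc4n(c3C2=O)[C@H]2OC[C@@H](O)[C@H]2OC4)cc1` gives 1560 nM
Compound 2 `O=C1C=C(N2CCC2)C(=O)c2c1nc1n2[C@H]2OC[C@@H](O)[C@H]2OC1` gives > 16000 nM (a limit of the assay, not a number)
Compound 3 `O=C1C(Nc2ccc(Br)cc2)=CC(=O)c2c1nc1n2[C@H]2OC[C@@H](O)[C@H]2OC1` gives 2020 nM

All three were tested in a functional assay on MGC-803 cells (Homo sapiens) for inhibition, read by sulforhodamine B assay (on this read-out higher numbers stand for weaker inhibition and lower numbers for stronger inhibition), and compound 2 gives only a limit there. Compound 3 at 2020 nM and compound 1 at 1560 nM lie within the usual scatter of each other. Compound 4 `COc1ccccc1NC1=CC(=O)c2c(nc3n2[C@H]2OC[C@@H](O)[C@H]2OC3)C1=O` keeps the shared core and has 2-methoxyphenyl in place of 4-bromophenyl on an amine nitrogen. Among the compounds with values here, no measured pair shows this swap, so compound 3 at 2020 nM and compound 1 at 1560 nM are the closest guides, and no change beyond the scatter is expected in this assay. The expected move is a 1.2-fold higher number from compound 3 to compound 4 (0.09 log units; within the scatter) and no more. For compound 4 the estimate is 2500 nM with an expected range from 900 nM to 7000 nM on repeat testing.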

Compound 4, half-maximal inhibitory concentration: 1670 nM
Compound 4: the middle estimate sits 1.5-fold (0.18 log units) above what was measured; measured number inside the range.
By their numbers in this assay, from the lowest: compounds 1, 4 and 3 (each within the scatter of the next). At a limit, above all of these: compound 2.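

In this assay, the swap on the amine nitrogen gives a 1.2-fold lower number from compound 3 to compound 4 (0.08 log units; within the scatter), so this step cannot separate 4-bromophenyl from 2-methoxyphenyl. Within the data shown here, it is the first direct one-place comparison at this position, and a ring carrying bromine reads the same as a ring carrying methoxy, even with the added hydrogen-bond acceptor. Nothing shown here offers a reason for this flat result.

Still open, as far as these compounds go, is whether other groups on this nitrogen would read the same. A benzyl group, a pyridine ring or a phenyl ring bearing a carboxylic acid might not.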